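Piperidine Urea in Place of Cyclopropyl Amide

This account rests on a few compounds, and the source may have more. Where it says the series, first, only, none or still open, it means among the compounds named here.

Measured so far:
compound 1, `O=C(C1CC1)N1CCc2nc(C#Cc3ccccc3)sc2C1`: 290 nM
compound 2, `O=S(=O)(N1CCCCC1)N1Cc2nc(C#Cc3ccccc3)sc2C1`: > 10000 nM

Of the compounds shown here, two have been tested in an assay on HEK293 cells for negative allosteric modulation of metabotropic glutamate receptor 5 (Homo sapiens), read by FLIPR, with a stated time of 1 h; a lower number here means a stronger inhibitor, a higher number a weaker inhibitor. Going by the values given here, compound 1 gives 290 nM and is the only compound here with a definite number. For compound 2 the result is a limit of the assay, not a number, at > 10000 nM; this is the limit of > 10000 nM in this assay, at which 1 of the 2 values shown sits. Among the compounds with values here, compound 2 also differs from compound 1 in more than one place, so the two values show only that one compound is measurable and the other is not.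

The next compound, compound 3, `O=C(N1CCCCC1)N1CCc2nc(C#Cc3ccccc3)sc2C1`, keeps the core of compound 1 and changes only the group on the carbonyl carbon: piperidin-1-yl in place of cyclopropyl on a carbonyl carbon.

Within the data shown here, no step between two measured compounds that differ in a single place is available, so the size of this change has to be guessed. A modest loss of potency is expected, with a step of a 2.8-fold higher number from compound 1 to compound 3 (0.44 log units; beyond the scatter) in this assay. The estimate for compound 3 is 800 nM, with a likely range from 150 nM to 5000 nM.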

Compound 3, half-maximal inhibitory concentration: > 10000 nM
Compound 3 ended at the assay's limit; the forecaster's own chance of this, stated with the estimate: 15%; middle value at least 12-fold (1.09 log units) from the limit.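

Going by these compounds alone, this is the first step in which only one place changes on the core of compound 1: in this assay, piperidin-1-yl in place of cyclopropyl on a carbonyl carbon gives an at least 34-fold higher number from compound 1 to compound 3 (1.53 log units; beyond the scatter). This position therefore does not accept every ring, since the cyclopropylcarbonyl form gives a definite number and the (piperidin-1-yl)carbonyl form does not. Compound 3 stands at a limit of the assay and not at a number, so the full size of the loss cannot be read: the limit of > 10000 nM in this assay, at which 2 of the 3 values shown sit.

Piperidin-1-yl differs from cyclopropyl both in ring size and in carrying a nitrogen, and the compounds shown do not separate these two differences. A cyclohexyl group on the same carbonyl carbon would keep a carbon-only ring while enlarging it, and a pyrrolidin-1-yl group would keep the ring nitrogen in a smaller ring, so either could show which of the two differences goes with the loss.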